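Sulfonyl substituent variation and cell tolerance in a macrocyclic series

The compounds below may be only part of what the source reports. "The series", "measured", "known", "first", "only" and "open" are said of these compounds alone.

Measured compounds:
compound 1, `COc1ccc2c(OCC[C@@H]3NC(=O)N(C)CCCC/C=C\[C@@H]4C[C@@]4(C(=O)NS(=O)(=O)C4(F)CC4)NC3=O)cc(-c3nc(C(C)C)cs3)nc2c1Cl`, 51400 nM;
compound 2, `C#C[C@@H]1CCCN1S(=O)(=O)NC(=O)[C@@]12C[C@H]1/C=C\CCCCN(C)C(=O)N[C@@H](CCOc1cc(-c3nc(C(C)C)cs3)nc3c(Cl)c(OC)ccc13)C(=O)N2`, 21200 nM;
compound 3, `COc1ccc2c(OCC[C@@H]3NC(=O)N(C)CCCC/C=C\[C@@H]4C[C@@]4(C(=O)NS(=O)(=O)C4CC4)NC3=O)cc(-c3nc(C(C)C)cs3)nc2c1Cl`, 40400 nM.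

In an ADME assay on cells (Homo sapiens) for activation (a higher number here means that more compound is tolerated, a lower number that less compound is tolerated), compound 3 stands second highest of the three; compound 1 lies nearest, a 1.3-fold lower number from compound 1 to compound 3 (0.10 log units; within the scatter), and compound 2 furthest, a 1.9-fold higher number from compound 2 to compound 3 (0.28 log units; within the scatter). Compound 4, `COc1ccc2c(OCC[C@@H]3NC(=O)N(C)CCCC/C=C\[C@@H]4C[C@@]4(C(=O)NS(=O)(=O)N4CCOCC4)NC3=O)cc(-c3nc(C(C)C)cs3)nc2c1Cl`, carries morpholin-4-yl in place of cyclopropyl on a sulfonyl sulfur. Among the measured compounds shown here, the step that bears on it is the one from compound 2 to compound 3, where a cyclic amine on the sulfonyl sulfur gave way to cyclopropyl, a 1.9-fold higher number from compound 2 to compound 3 (0.28 log units; within the scatter); the step of a 2.4-fold lower number from compound 1 to compound 2 (0.38 log units; beyond the scatter) points the same way. Compound 4 reverses that direction, so a small drop in this assay is expected, close to the scatter: a 1.3-fold lower number from compound 3 to compound 4 (0.13 log units; within the scatter). Compound 4 is estimated at 30000 nM, between 14000 nM and 65000 nM.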

Compound 4, half-maximal cytotoxic concentration: 26400 nM
Estimate against measurement, compound 4: 1.1-fold (0.06 log units) above; measured number inside the range.
By their numbers in this assay, from the lowest: compounds 2, 4, 3 and 1 (each within the scatter of the next, the first and the last beyond it).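

Morpholin-4-yl in place of cyclopropyl on a sulfonyl sulfur stays within the scatter in this assay (a 1.5-fold lower number from compound 3 to compound 4 (0.18 log units; within the scatter)), and compound 4 also lies within the scatter of both compounds that differ most, compound 2 (a 1.2-fold higher number from compound 2 to compound 4 (0.10 log units; within the scatter)) and compound 1 (a 1.9-fold lower number from compound 1 to compound 4 (0.29 log units; within the scatter)). This position therefore takes a six-membered ring with two hetero atoms without a step beyond the scatter. Nothing measured here accounts for these numbers.

Going by these compounds, whether a dimethylamino group or a carboxylic acid on the sulfonyl sulfur would give a step beyond the scatter remains open.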